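The source may hold more compounds than are shown below. What is called first, only, known or untested is meant among the compounds shown, and "the series" means these compounds.

Three members of the series are measured so far. Compound 1 `COc1c(OCCCCN2CCN(C)CC2)cc(O)c2c(=O)cc(-c3ccc(C)cc3)oc12` gives 1000 nM in a functional assay on HepG2 cells (Homo sapiens) for cytotoxicity, read by MTT assay, with a stated time of 72 h; a higher number here means a weaker inhibitor, a lower number a stronger inhibitor. Compound 2 `COc1c(OCCCCN2CCN(C)CC2)cc(O)c2c(=O)cc(-c3ccc(Br)cc3)oc12` gives 2320 nM, a change that reads a 2.3-fold higher number from compound 1 to compound 2 (0.37 log units; beyond the scatter). Compound 3 `CN(C)CCCOc1c(OCc2ccccc2)cc(O)c2c(=O)cc(-c3ccccc3)oc12` gives 4950 nM, the highest of the three numbers, with compound 2 nearest and compound 1 furthest from it. Compound 4 `CCN(CC)CCCCOc1c(OCc2ccccc2)cc(O)c2c(=O)cc(-c3ccccc3)oc12` differs from compound 3 by (diethylamino)methyl in place of dimethylamino on a saturated chain carbon, three bonds along the chain from an oxygen on an aromatic ring. For the measured compounds named here, the single step on record, a 2.3-fold higher number from compound 1 to compound 2 (0.37 log units; beyond the scatter), concerns an aromatic substituent and does not bear on this amine end of the chain; no measured pair touches it. With nothing to go on, the expected step is no change at the digits printed from compound 3 to compound 4 (within the scatter), not beyond the scatter. Compound 4 is therefore estimated at 4950 nM in this assay, between 1800 nM and 13500 nM.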

Compound 4, half-maximal inhibitory concentration: 1650 nM
Compound 4: the middle estimate sits 3.0-fold (0.48 log units) above what was measured; measured number outside the range, below it.
By their numbers in this assay, from the lowest: compounds 1, 4 and 2 (each within the scatter of the next, the first and the last beyond it); then compound 3.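

In this assay the amine end of the chain proves able to move the number: going from 3-(dimethylamino)propyl to 4-(diethylamino)butyl gives a 3.0-fold lower number from compound 3 to compound 4 (0.48 log units; beyond the scatter), the first step read at this position. This change alters the chain and the groups on its nitrogen together, so the step cannot be divided between them. Nothing at hand gives a reason for the step.

Open, from the compounds shown here alone, is whether the step follows the chain or the nitrogen groups, which a butyl chain ending in dimethylamino or a propyl chain ending in diethylamino would separate. Also open, going by these compounds, is how a morpholine at the chain end would read on this core.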